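Swapping a Benzoylethenyl Arm for a Phenylcyclopropyl Arm

A few compounds are considered here, and "the series" means these few. Any claim that something is new, unique, unknown or untested is made for them only; others in the source may bear on it.

Of the compounds shown here, three built on one shared core have been measured in an assay for binding affinity to Adrenergic receptor alpha-1 (Rattus norvegicus); a lower number here means a stronger inhibitor, a higher number a weaker inhibitor. Compound 1 `COc1cc2nc(N3CCN(C(=O)/C=C/c4cccc(F)c4)CC3)nc(N)c2cc1OC` gives 20.9 nM, and compound 2 `COc1cc2nc(N3CCN(C(=O)COc4ccccc4)CC3)nc(N)c2cc1OC` gives 12.6 nM; the step of a 1.7-fold lower number from compound 1 to compound 2 (0.22 log units; within the scatter) is within the scatter. Compound 3 `COc1cc2nc(N3CCN(C(=O)/C=C/C(=O)c4ccccc4)CC3)nc(N)c2cc1OC` gives 87.1 nM, the highest of the three numbers, and both steps leading to it, a 4.2-fold higher number from compound 1 to compound 3 (0.62 log units; beyond the scatter) and a 6.9-fold higher number from compound 2 to compound 3 (0.84 log units; beyond the scatter), lie beyond the scatter.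

Compound 4 `COc1cc2nc(N3CCN(C(=O)C4CC4c4ccccc4)CC3)nc(N)c2cc1OC` has not yet been measured. It differs from compound 3 in one place: 2-phenylcyclopropyl in place of 2-benzoylethenyl on a carbonyl carbon. The two measured steps that bear on this are the ones into compound 3, each of which paired the arrival of the 2-benzoylethenyl arm, with its carbonyl acceptor, with a modest rise in the number. Compound 4 gives that acceptor up and carries a phenyl on a small ring instead, so a move back toward the numbers of compound 1 and compound 2 is expected, as a 3.5-fold lower number from compound 3 to compound 4 (0.54 log units; beyond the scatter). Compound 4 is estimated at 25 nM, with a likely range from 8 nM to 80 nM.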

Compound 4, half-maximal inhibitory concentration: 0.513 nM
Compound 4: the middle estimate sits 49-fold (1.69 log units) above what was measured; the whole stated range lies above it.
By their numbers in this assay, from the lowest: compound 4; then compounds 2 and 1 (each within the scatter of the next); then compound 3.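

In this assay, going by these compounds alone, the arm on the carbonyl carbon proves able to shift the number far more than the earlier compounds showed, with the largest step running (a 170-fold lower number from compound 3 to compound 4 (2.23 log units; beyond the scatter)). The 2-phenylcyclopropyl arm also stands apart from the other two arms (a 25-fold lower number from compound 2 to compound 4 (1.39 log units; beyond the scatter); a 41-fold lower number from compound 1 to compound 4 (1.61 log units; beyond the scatter)), and since the arm of compound 1 has no benzoyl carbonyl either, losing that carbonyl cannot alone account for the result. Nothing measured here explains why this arm gives so low a number.

From the compounds shown here alone, what remains open is whether the three-membered ring or its phenyl matters more, a question that a plain cyclopropyl and a 2-phenylethyl arm could help separate. Also open, going by these compounds, is how substituents on that phenyl, such as an amine or a carboxylic acid, would change the number.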